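The source may hold more compounds than are shown below. What is called first, only, known or untested is meant among the compounds shown, and "the series" means these compounds.

In a functional assay on MV4-11 cells (Homo sapiens) for antiproliferative activity, read by CCK-8 assay, with a stated time of 72 h (a lower number here means a stronger inhibitor, a higher number a weaker inhibitor), compound 1 `COc1ccc(C(C)(C)O)cc1-c1cn(C)c(=O)c2[nH]c(C(=O)NCc3ccc(C(=O)Nc4ccccc4N)cc3)cc12` gives 420 nM. Compound 2 `Cn1cc(-c2ccc(F)cc2)c2cc(C(=O)NCc3ccc(C(=O)Nc4ccccc4N)cc3)[nH]c2c1=O` gives 220 nM, which puts the two within the usual scatter of each other. Compound 3 `COc1ccccc1-c1cn(C)c(=O)c2[nH]c(C(=O)NCc3ccc(C(=O)Nc4ccccc4N)cc3)cc12` has not yet been measured, and it differs from compound 2 on one aromatic carbon: 2-methoxyphenyl in place of 4-fluorophenyl on an aromatic carbon. Among the compounds with values here, the only measured step at this place, a 1.9-fold lower number from compound 1 to compound 2 (0.28 log units; within the scatter), exchanged 5-(1-hydroxy-1-methylethyl)-2-methoxyphenyl for 4-fluorophenyl and stayed within the scatter. No clear change is therefore expected in this assay, and the expected size is a 1.4-fold higher number from compound 2 to compound 3 (0.13 log units; within the scatter). For compound 3 the estimated value is 300 nM, with an expected range of 120 nM to 750 nM.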

Compound 3, half-maximal inhibitory concentration: 200 nM
The estimate for compound 3 lay 1.5-fold (0.18 log units) above the measured number; the measured number falls inside the stated range.
By their numbers in this assay, from the lowest: compounds 3, 2 and 1 (each within the scatter of the next, the first and the last beyond it).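

In this assay, 2-methoxyphenyl and 4-fluorophenyl cannot be told apart at this position, with a 1.1-fold lower number from compound 2 to compound 3 (0.04 log units; within the scatter) staying within the scatter. Within the data shown here, removing the 1-hydroxy-1-methylethyl group from the 2-methoxyphenyl ring gives a 2.1-fold lower number from compound 1 to compound 3 (0.32 log units; beyond the scatter) and is the first step here to go beyond the scatter, though only modestly. No measurement at hand explains either step. The compounds shown leave open how an amine or a carboxylic acid in place of that 1-hydroxy-1-methylethyl group would compare, and whether a methoxy group on the ring matters at all next to plain phenyl.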